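The compounds below may be only part of what the source reports. "The series", "measured", "known", "first", "only" and "open" are said of these compounds alone.

Working notes on the series. In a functional assay on the whole organism for inhibition, with Rattus norvegicus as the target (on this read-out lower numbers stand for an effect already at smaller amounts and higher numbers for an effect only at larger amounts of compound), compound 1 `CC1CCC(=NNc2ccccc2)c2ncc(C(=O)O)c(=O)n21` gives 1.2 umol/kg. Compound 2 `CC1CCn2c(ncc(C(=O)O)c2=O)/C1=N/Nc1ccccc1` has the same groups arranged on a shifted core. In this assay compound 2 returns only a limit, > 320 umol/kg, which is a bound of the measurement and not a number. Compound 3 `CC1CC/C(=N\Nc2ccccc2F)c2ncc(C(=O)O)c(=O)n21` carries a 2-fluorophenyl on the amine nitrogen. In this assay compound 3 also returns only a limit, > 1000 umol/kg, again a bound and not a number. Compound 3 therefore stands at the limit of > 1000 umol/kg in this assay, at which 1 of the 3 values shown sits. Compound 2 stands at the limit of > 320 umol/kg in this assay, at which 1 of the 3 values shown sits. Only compound 1 has a true number among the three.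

Compound 4 `CC1CC/C(=N\Nc2cccc(Cl)c2)c2ncc(C(=O)O)c(=O)n21` differs from compound 3 in one place: 3-chlorophenyl in place of 2-fluorophenyl on an amine nitrogen. For the measured compounds named here, no pair of measured compounds differing in a single place exists in this set, so no measured step gives the size of such an exchange. Compound 1 with plain phenyl gives 1.2 umol/kg, which shows that this core can act at small doses. Compound 3, by contrast, sits at a limit. The step of an at least 25-fold lower number from compound 3 to compound 4 (1.39 log units; beyond the scatter) is expected to run toward smaller doses, though with wide uncertainty and a real chance of another limit. Compound 4 is estimated at 40 umol/kg, with a range from 3 umol/kg to 1000 umol/kg.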

Compound 4, dose for 50% inhibition: > 100 umol/kg
Compound 4 ended at the assay's limit; the forecaster's own chance of this, stated with the estimate: 35%; at least 2.5-fold (0.39 log units) between middle value and limit.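

For the compounds shown here, compound 3 and compound 4 both return only limits in this assay, which are bounds and not numbers, so no step between them can be read. The compounds shown leave open how 2-fluorophenyl and 3-chlorophenyl on an amine nitrogen differ from each other, and how far either lies from the plain phenyl of compound 1 at 1.2 umol/kg.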